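This account rests on a few compounds, and the source may have more. Where it says the series, first, only, none or still open, it means among the compounds named here.

Compound 1, `CN(C)CCCCCCCCOc1ccc2oc(-c3ccccc3)cc(=O)c2c1`, is examined in an assay on isolated protein (Cavia porcellus) with Sigma non-opioid intracellular receptor 1 (Homo sapiens) as the target, read by radioligand binding (a lower number here means a stronger inhibitor, a higher number a weaker inhibitor), where compound 1 gives 227 nM. Among the three compounds measured so far, that is the highest number: compound 2, `O=c1cc(-c2ccc(F)cc2)oc2ccc(OCCCCCCN3CCC(O)CC3)cc12`, gives 95 nM, and compound 3, `O=c1cc(C2CCCCC2)oc2ccc(OCCCCCCN3CCCCC3)cc12`, gives 55 nM, and both of these gaps from compound 1 lie beyond the usual scatter. Compound 4, `NCCCCCCOc1ccc2oc(-c3ccccc3)cc(=O)c2c1`, differs from compound 1 in a single place: amino in place of 2-(dimethylamino)ethyl on a saturated chain carbon, six bonds along the chain from an oxygen on an aromatic ring. Within the data shown here, no measured pair shows this same change, so its effect cannot be read from the data. The step from compound 1 to compound 4 is expected to move toward a higher number, a 3.1-fold higher number from compound 1 to compound 4 (0.49 log units; beyond the scatter), beyond the scatter. Compound 4 is therefore estimated to give 700 nM in this assay, within a range from 200 nM to 2500 nM.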

Compound 4, half-maximal inhibitory concentration: 2100 nM
Estimate against measurement, compound 4: 3.0-fold (0.48 log units) below, within the range that was stated.
By their numbers in this assay, from the lowest: compounds 3 and 2 (each within the scatter of the next); then compound 1; then compound 4.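

Among these compounds, the step from the opening compound is the first measured change at this place on the chain. In this assay, amino in place of 2-(dimethylamino)ethyl weakens the compound, with a 9.3-fold higher number from compound 1 to compound 4 (0.97 log units; beyond the scatter). This one change swaps five heavy atoms for one, so it joins a shorter chain end with the loss of the dimethylamino group, and no supporting data explain the size of the step. Open, from the compounds shown here alone, is how dimethylamino or 2-aminoethyl would read at this same place, which would separate the two parts of the change.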